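Swapping a methyl for dimethylamino on the aryl ether

This account rests on a few compounds, and the source may have more. Where it says the series, first, only, none or still open, it means among the compounds named here.

Three compounds share one core and differ only in the group attached through the oxygen. Compound 1 `Cc1ccccc1COc1ccc(N2CCC[C@H]2CC(=O)O)cc1` gives 190 nM in a functional assay on cells for agonist activity at Free fatty acid receptor 1 (Homo sapiens), read by FLIPR and calcium flux, with a stated time of 100 s; on this read-out lower numbers stand for an effect already at smaller amounts and higher numbers for an effect only at larger amounts of compound. Compound 2 `Cc1ccccc1Oc1ccc(N2CCC[C@H]2CC(=O)O)cc1` gives 74 nM in this assay, and compound 3 `Cc1cccc(Oc2ccc(N3CCC[C@H]3CC(=O)O)cc2)c1` gives 260 nM. The step of a 2.6-fold lower number from compound 1 to compound 2 (0.41 log units; beyond the scatter) is clear, as is a 3.5-fold higher number from compound 2 to compound 3 (0.55 log units; beyond the scatter), whereas a 1.4-fold higher number from compound 1 to compound 3 (0.14 log units; within the scatter) lies within the scatter, so compound 3 and compound 1 cannot be told apart, while compound 3 sits clearly apart from compound 2.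

Compound 4 `CN(C)c1cccc(Oc2ccc(N3CCC[C@H]3CC(=O)O)cc2)c1` arises from compound 3 by dimethylamino in place of methyl on an aromatic carbon. Among the measured compounds shown here, none of the measured steps exchanges a methyl for dimethylamino; they only move or shorten the link to the methylphenyl group. The measured steps therefore give no direct guide, and the change replaces a group of one heavy atom with a group of three heavy atoms carrying a hydrogen-bond acceptor, which leaves the direction open. A step of modest size at most is expected in this assay, and most likely none beyond the scatter. Compound 4 is estimated at 320 nM, with a range from 100 nM to 1000 nM, which corresponds to the expected step of a 1.2-fold higher number from compound 3 to compound 4 (0.09 log units; within the scatter).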

Compound 4, half-maximal effective concentration: 1300 nM
Estimate against measurement, compound 4: 4.1-fold (0.61 log units) below, outside the stated range (above it).
By their numbers in this assay, from the lowest: compound 2; then compounds 1 and 3 (each within the scatter of the next); then compound 4.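

Exchanging methyl for dimethylamino on this aromatic carbon, meta to a large group, gives a 5.0-fold higher number from compound 3 to compound 4 (0.70 log units; beyond the scatter) in this assay. The earlier compounds shown here changed only the link to the methylphenyl group and where its methyl sits, whereas this step shows that the identity of the group on this carbon also matters, and that here the larger group with a nitrogen goes with a higher number. Nothing shown explains why this exchange has that effect.

The compounds shown leave open whether the nitrogen or the two extra heavy atoms matter more, a question that an ethyl group, a methoxy group or a plain amino group on the same carbon could help to answer. They also leave open whether the same exchange would have a similar effect on compound 2.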